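The source may hold more compounds than are shown below. What is called first, only, known or untested is meant among the compounds shown, and "the series" means these compounds.

Compound 1 `CC(C)(C)c1nnc(-c2ccc(N3CCC(Oc4ccccc4C(F)(F)F)CC3)nn2)s1` gives 710 nM in an assay on microsomes from liver for inhibition of acyl-CoA desaturase 1 (Rattus norvegicus); a lower number here means a stronger inhibitor, a higher number a weaker inhibitor. Compound 2 `CC(C)Cc1nnc(-c2ccc(N3CCC(Oc4ccccc4C(F)(F)F)CC3)nn2)s1` gives 37 nM. Compound 3 `FC(F)(F)c1ccccc1OC1CCN(c2ccc(-c3nnco3)nn2)CC1` gives 22 nM.

Among these three numbers compound 3 stands lowest, though its gap to compound 2 lies within the scatter; only compound 1 sits clearly apart, since there is a 32-fold lower number from compound 1 to compound 3 (1.51 log units; beyond the scatter). Compound 4 `CC(C)Cc1nnc(-c2ccc(N3CCC(Oc4ccccc4C(F)(F)F)CC3)nn2)o1` differs from compound 3 by isobutyl in place of hydrogen on an aromatic carbon. Among the measured compounds shown here, two measured steps bear on this. Within the core of compound 1, there was a 19-fold lower number from compound 1 to compound 2 (1.28 log units; beyond the scatter). Between the isobutyl-bearing compound 2 and the unsubstituted compound 3 there was a 1.7-fold lower number from compound 2 to compound 3 (0.23 log units; within the scatter), so carrying an isobutyl group did not set compound 2 apart from compound 3. For compound 4 the expected outcome is therefore no step beyond the scatter: a 1.1-fold lower number from compound 3 to compound 4 (0.04 log units; within the scatter). The estimate for compound 4 is 20 nM, within 8 nM to 50 nM.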

Compound 4, half-maximal inhibitory concentration: 15 nM
For compound 4 the middle estimate is 1.3-fold (0.12 log units) above the measured one, and the stated range covers the measured number.
By their numbers in this assay, from the lowest: compounds 4, 3 and 2 (each within the scatter of the next, the first and the last beyond it); then compound 1.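

In this assay, isobutyl on the oxadiazole carbon gives a 1.5-fold lower number from compound 3 to compound 4 (0.17 log units; within the scatter), so this position accepts the chain with no step beyond the scatter. With isobutyl on both compounds, the 5-isobutyl-1,3,4-oxadiazol-2-yl group in place of its thiadiazole counterpart gives a 2.5-fold lower number from compound 2 to compound 4 (0.39 log units; beyond the scatter), while changing both ring and chain gives a 47-fold lower number from compound 1 to compound 4 (1.68 log units; beyond the scatter). No evidence is available to explain these steps. Going by these compounds, whether an amine, a carboxylic acid or a longer chain on this carbon would be accepted as well remains open.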